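Swapping the Thiophene Attachment Point on a Weak Growth Inhibitor

A few compounds are considered here, and "the series" means these few. Any claim that something is new, unique, unknown or untested is made for them only; others in the source may bear on it.

Compound 1, `N=C(N)N/N=C/c1c(-c2cccs2)nc2n1CCS2`, gives 39800 nM in a functional assay on cells (Cancer cell lines, Homo sapiens) for inhibition; a higher number here means a weaker inhibitor of growth, a lower number a stronger inhibitor of growth.
Compound 2, `N=C(N)N/N=C/c1c(-c2cccs2)nc2sccn12`, gives 10200 nM in this assay.
Compound 3, `N=C(N)N/N=C/c1c(-c2ccsc2)nc2sccn12`, gives 15500 nM in this assay.

Among these three, compound 1 has the highest number, so it is the weakest growth inhibitor; its gap to compound 3 and its larger gap to compound 2 both lie beyond the scatter. Compound 4, `N=C(N)N/N=C/c1c(-c2ccsc2)nc2n1CCS2`, has not yet been measured. It differs from compound 1 in one place: thiophen-3-yl in place of thiophen-2-yl on an aromatic carbon.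

Among the compounds with values here, one measured step bears on this change, the same swap made on a different core: a 1.5-fold higher number from compound 2 to compound 3 (0.18 log units; within the scatter). That step stayed within the scatter, so the same swap on compound 1 is expected to move the number little, if at all, with a slight lean toward a higher value.

The step from compound 1 to compound 4 is therefore estimated as a 1.4-fold higher number from compound 1 to compound 4 (0.14 log units; within the scatter). For compound 4 the expected value in this assay is 55000 nM, with a range from 25000 nM to 120000 nM.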

Compound 4, concentration for 50% growth inhibition: 14500 nM
Beside the measured number, compound 4's estimate is 3.8-fold (0.58 log units) above it; measured number below the stated range.
By their numbers in this assay, from the lowest: compounds 2, 4 and 3 (each within the scatter of the next); then compound 1.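

Thiophen-3-yl in place of thiophen-2-yl is not a silent change at this position on every core: here it brings a 2.7-fold lower number from compound 1 to compound 4 (0.44 log units; beyond the scatter). The earlier compounds shown here showed this change only on the core shared by compound 2 and compound 3, where it stayed within the scatter. Within these four compounds, then, the size and direction of the change depend on the core that carries it, and a step read on one core does not carry over to the other: the same change on two cores in this assay, a 1.5-fold higher number (0.18 log units; within the scatter) from compound 2 to compound 3 and a 2.7-fold lower number (0.44 log units; beyond the scatter) from compound 1 to compound 4, 4.2-fold (0.62 log units) apart, beyond the scatter of two such steps

As far as these compounds go, it remains open whether a phenyl ring, a furan-2-yl group or a small amine at this position would also behave differently on the two cores. With only two thiophene attachments shown here, it is also unknown whether any other group would give a stronger growth inhibitor on either core.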